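Nitro to Chloro: Little Change Expected in Cell Growth

The compounds below may be only part of what the source reports. "The series", "measured", "known", "first", "only" and "open" are said of these compounds alone.

Measured compounds:
compound 1 `O=Cc1cn(-c2ccccc2)nc1-c1ccc([N+](=O)[O-])cc1`: 97%
compound 2 `O=Cc1cn(-c2ccccc2)nc1-c1ccccc1O`: 97%
compound 3 `COc1cc(/C=C/C(=O)C(=Cc2cn(-c3ccccc3)nc2-c2ccc([N+](=O)[O-])cc2)C(=O)/C=C/c2ccc(O)c(OC)c2)ccc1O`: 98%

All three were tested in a functional assay on MCF7 cells (Homo sapiens) for antiproliferative activity, read by MTT assay, with a stated time of 24 h, tested at 0.001 ug/mL; on this read-out lower numbers stand for a stronger effect and higher numbers for a weaker effect at the one concentration tested. Compound 3 gives 98%. Compound 1 gives 97%. Compound 2 gives 97%. Compound 3 carries the highest of the three numbers, yet its gaps to compound 1 and to compound 2 lie within the usual scatter, so the three cannot be told apart, and none shows a clear effect at this concentration.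

Compound 4 `COc1cc(/C=C/C(=O)C(=Cc2cn(-c3ccccc3)nc2-c2ccc(Cl)cc2)C(=O)/C=C/c2ccc(O)c(OC)c2)ccc1O` differs from compound 3 in one place: chloro in place of nitro on an aromatic carbon. Within the data shown here, no measured pair shows the effect of such a change here. In this assay the step of a number 1 percentage points lower from compound 3 to compound 4 (within the scatter) is expected to be none beyond the scatter. Compound 4 is therefore estimated at 97%, between 90% and 103%.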

Compound 4, a percentage reported as activity, at one concentration (the size of the read-out at that concentration, not a potency): 81%
Beside the measured number, compound 4's estimate is 16 percentage points above it; measured number outside the range, below it.
By their numbers in this assay, from the lowest: compound 4; then compounds 1, 2 and 3 (each within the scatter of the next).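

In this assay, among these compounds, chloro in place of nitro on the aromatic carbon gives a number 17 percentage points lower from compound 3 to compound 4 (beyond the scatter), the only step here beyond the scatter. Among the compounds shown here, the group at this place therefore does affect the read-out, which the earlier compounds, all within the scatter of one another, could not reveal. No measurement at hand gives a reason for this step.

Going by these compounds, whether an amine or a fluoro at the same place would lower the number further remains open. So does whether the same swap would do anything on the smaller compound 1.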